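A few compounds are considered here, and "the series" means these few. Any claim that something is new, unique, unknown or untested is made for them only; others in the source may bear on it.

Measured compounds in a functional assay on MDA-MB-231 cells (Homo sapiens) for cytotoxicity, read by MTT assay, with a stated time of 72 h; a lower number here means a stronger inhibitor, a higher number a weaker inhibitor:
compound 1 `CC1CCN(Cc2ccc3nc(NC(=O)N/N=C/c4c[nH]c5ccccc45)sc3c2)CC1` gives 2460 nM
compound 2 `CCN(CC)Cc1ccc2nc(NC(=O)N/N=C/c3c[nH]c4ccccc34)sc2c1` gives 1900 nM

Compound 1 has the highest of the two numbers, but the step of a 1.3-fold lower number from compound 1 to compound 2 (0.11 log units; within the scatter) lies within the scatter, so no order between compound 1 and compound 2 can be claimed. Compound 3 `CC1CCN(Cc2ccc3nc(NC(=O)N/N=C/c4cn(Cc5ccc(C(C)(C)C)cc5)c5ccccc45)sc3c2)CC1` differs from compound 1 by 4-(tert-butyl)benzyl in place of hydrogen on an aromatic nitrogen. Going by the values given here, no measured step bears on a change at this aromatic nitrogen; the single measured step concerns only the amine on the saturated chain carbon. The step of a 1.2-fold lower number from compound 1 to compound 3 (0.09 log units; within the scatter) is therefore expected to be small, with a wide range of uncertainty. For compound 3 the estimate in this assay is 2000 nM, range 500 nM to 8000 nM.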

Compound 3, half-maximal inhibitory concentration: 3880 nM
The estimate for compound 3 lay 1.9-fold (0.29 log units) below the measured number, within the range that was stated.
By their numbers in this assay, from the lowest: compounds 2, 1 and 3 (each within the scatter of the next, the first and the last beyond it).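

Putting 4-(tert-butyl)benzyl in place of hydrogen on the aromatic nitrogen gives a 1.6-fold higher number from compound 1 to compound 3 (0.20 log units; within the scatter) in this assay. In this pair, the aromatic nitrogen carries a group of 11 heavy atoms, including a six-membered aromatic ring, without a step beyond the scatter, so the hydrogen there is not needed to keep the number within that scatter. Nothing available accounts for this result.

As far as these compounds go, whether a methyl, a longer chain ending in an amine, or a carboxylic acid on this nitrogen behaves alike remains open. Also open, from the compounds shown here alone, is how the benzyl group reads alongside diethylamino in place of 4-methylpiperidin-1-yl.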